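Tert-butyl for methoxy on the urea phenyl

The source may report more compounds than this note shows. Statements on the series, on what has been measured and on what is new or still open speak of the compounds shown alone.

Compound 2 `COc1ccc(NC(=O)Nc2cccc(CNc3ncnc4cc(OC)c(OC)cc34)c2)cc1` carries a shared core with compound 1 `COc1ccccc1NC(=O)Nc1cccc(CNc2ncnc3cc(OC)c(OC)cc23)c1` and differs from it only on the urea nitrogen, where a 4-methoxyphenyl stands in place of a 2-methoxyphenyl. In a functional assay on MGC-803 cells (Homo sapiens) for antiproliferative activity, read by MTT assay (a higher number here means a weaker inhibitor, a lower number a stronger inhibitor), compound 2 gives 12300 nM, the highest of the two numbers recorded, while compound 1 gives 7710 nM; the step of a 1.6-fold higher number from compound 1 to compound 2 (0.20 log units; within the scatter) sits within the scatter, so the two compounds cannot be ranked. Compound 3 `COc1cc2ncnc(NCc3cccc(NC(=O)Nc4ccc(C(C)(C)C)cc4)c3)c2cc1OC` arises from compound 2 by tert-butyl in place of methoxy on an aromatic carbon. Within the data shown here, no measured step changes this group; the only step available, from compound 1 to compound 2, moved a methoxy around the ring without exchanging it. On that basis the expected step of a 1.4-fold lower number from compound 2 to compound 3 (0.14 log units; within the scatter) is not beyond the scatter, although the evidence is thin. Compound 3 is therefore estimated at 9000 nM, with a range from 2500 nM to 35000 nM.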

Compound 3, half-maximal inhibitory concentration: 6790 nM
Beside the measured number, compound 3's estimate is 1.3-fold (0.12 log units) above it; the range from low to high includes it.
By their numbers in this assay, from the lowest: compounds 3, 1 and 2 (each within the scatter of the next).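

In this assay, this aromatic carbon of the urea phenyl takes tert-butyl, with 4 heavy atoms and 0 hydrogen-bond acceptors, in place of methoxy, with 2 heavy atoms and 1 hydrogen-bond acceptor, and the exchange gives a 1.8-fold lower number from compound 2 to compound 3 (0.26 log units; within the scatter) without a step that can be read as a real difference. Set against the 2-methoxyphenyl, the 4-(tert-butyl)phenyl on the amide-type nitrogen gives a 1.1-fold lower number from compound 1 to compound 3 (0.06 log units; within the scatter) and so adds a third aryl group that cannot be ranked against the other two. Nothing available accounts for how close these numbers lie.

The compounds shown leave open whether any group on this aromatic carbon can move the number beyond the scatter. An amine or a carboxylic acid in place of tert-butyl would put that question to a group of a different kind.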